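Trifluoromethoxy placement on the aryl sulfone

A few compounds are considered here, and "the series" means these few. Any claim that something is new, unique, unknown or untested is made for them only; others in the source may bear on it.

Measured in a functional assay on DU-145 cells (Homo sapiens) for antiproliferative activity, read by propidium iodide staining, with a stated time of 96 h; a lower number here means a stronger inhibitor, a higher number a weaker inhibitor:
- compound 1 `CC(O)(CS(=O)(=O)c1ccccc1C(F)(F)F)C(=O)Nc1cccc(S(F)(F)(F)(F)F)c1`: 27300 nM
- compound 2 `CC(O)(CS(=O)(=O)c1ccc(OC(F)(F)F)cc1)C(=O)Nc1cccc(S(F)(F)(F)(F)F)c1`: 35600 nM
- compound 3 `CC(O)(CS(=O)(=O)c1cccc(OC(F)(F)F)c1)C(=O)Nc1cccc(S(F)(F)(F)(F)F)c1`: 31500 nM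

In this assay compound 3 gives 31500 nM, within the scatter of both other compounds, so the three values cannot be ranked.

The next structure, compound 4 `CC(O)(CS(=O)(=O)c1ccccc1OC(F)(F)F)C(=O)Nc1cccc(S(F)(F)(F)(F)F)c1`, differs from compound 3 as follows: 2-(trifluoromethoxy)phenyl in place of 3-(trifluoromethoxy)phenyl on a sulfonyl sulfur. In words, this places 2-(trifluoromethoxy)phenyl in place of 3-(trifluoromethoxy)phenyl on a sulfonyl sulfur.

Among the measured compounds shown here, three measured steps bear on this change, all on the same group. Placing 3-(trifluoromethoxy)phenyl in place of 4-(trifluoromethoxy)phenyl gave a 1.1-fold lower number from compound 2 to compound 3 (0.05 log units; within the scatter). The two exchanges from 2-(trifluoromethyl)phenyl gave a 1.3-fold higher number from compound 1 to compound 2 (0.12 log units; within the scatter) and a 1.2-fold higher number from compound 1 to compound 3 (0.06 log units; within the scatter). All three lie within the scatter, so no step beyond the scatter is expected in this assay.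

The expected step is a 1.1-fold lower number from compound 3 to compound 4 (0.02 log units; within the scatter).

Compound 4 is estimated at 30000 nM, with an expected range of 17000 nM to 55000 nM.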

Compound 4, half-maximal inhibitory concentration: 29100 nM
Estimate against measurement, compound 4: 1.0-fold (0.01 log units) above, within the range that was stated.
By their numbers in this assay, from the lowest: compounds 1, 4, 3 and 2 (each within the scatter of the next).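

With 2-(trifluoromethoxy)phenyl on the sulfonyl sulfur, the series now holds three placements of trifluoromethoxy, and in this assay the two new exchanges of placement (a 1.1-fold lower number from compound 3 to compound 4 (0.03 log units; within the scatter) and a 1.2-fold lower number from compound 2 to compound 4 (0.09 log units; within the scatter)) both stay within the scatter, so compounds 2, 3 and 4 show no dependence on placement. Among the compounds shown here, the exchange of trifluoromethyl for trifluoromethoxy on an aromatic carbon can now be read on its own (a 1.1-fold higher number from compound 1 to compound 4 (0.03 log units; within the scatter)) and is also within the scatter, whereas the earlier compounds offered it only together with a change of placement. Nothing available explains why these values lie so close together.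

Open, going by these compounds, is whether an amine or a carboxylic acid on the phenyl ring, or a longer chain in place of that ring, would give a step beyond the scatter in this assay.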